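Sulfonyl Substituent Exchange in a Tracheal Functional Series

The source may hold more compounds than are shown below. What is called first, only, known or untested is meant among the compounds shown, and "the series" means these compounds.

Of the compounds shown here, two of this set have been measured in a functional assay on the whole organism (trachea) with Rattus norvegicus as the target; on this read-out lower numbers stand for smaller maximal responses and higher numbers for larger maximal responses. Compound 1 `CC1(C)C=C(n2ccccc2=O)c2cc(S(=O)(=O)Nc3ccc(C#N)cc3)ccc2O1` gives 90.8%. Compound 2 `CN(C)S(=O)(=O)c1ccc2c(c1)C(n1ccccc1=O)=CC(C)(C)O2` gives 74.1%. Compound 2 therefore stands lowest of the two numbers; its nearest neighbour is compound 1, and the step of a number 16.7 percentage points lower from compound 1 to compound 2 (beyond the scatter) lies beyond the scatter. Compound 3 `CC1(C)C=C(n2ccccc2=O)c2cc(S(=O)(=O)N3CCOCC3)ccc2O1` has not yet been measured. It differs from compound 2 in one place: morpholin-4-yl in place of dimethylamino on a sulfonyl sulfur. Within the data shown here, only one measured step touches this sulfonyl sulfur, namely a number 16.7 percentage points lower from compound 1 to compound 2 (beyond the scatter), which was modest and ran downward when (4-cyanophenyl)amino gave way to dimethylamino. Among the measured compounds shown here, the exchange of dimethylamino for morpholin-4-yl at the same sulfonyl sulfur has no direct precedent here, so the expected step is a number 4.1 percentage points lower from compound 2 to compound 3 (within the scatter), that is, little or no change beyond the scatter, with a slight lean downward. For compound 3 the estimate is 70%, with a range from 55% to 85%.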

Compound 3, largest response reached (Emax), in percent of the reference or control that the assay uses: 85.1%
Compound 3: the middle estimate sits 15.1 percentage points below what was measured; the whole stated range lies below it.
By their numbers in this assay, from the lowest: compound 2; then compounds 3 and 1 (each within the scatter of the next).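

In this assay, exchanging dimethylamino for morpholin-4-yl on the sulfonyl sulfur gives a number 11 percentage points higher from compound 2 to compound 3 (beyond the scatter), so this position responds even to a change between two groups that both lack a hydrogen-bond donor. The comparison with the (4-cyanophenyl)amino group gives a number 5.7 percentage points lower from compound 1 to compound 3 (within the scatter), which means the drop seen with dimethylamino does not extend to morpholin-4-yl, and the donor carried by compound 1 is not needed to stay within the scatter of its number. No measurement shown accounts for the difference between dimethylamino and morpholin-4-yl.

The compounds shown leave open whether the ring itself or its oxygen goes with the higher number, a question that a piperidin-1-yl group on the same sulfonyl sulfur would address. As far as these compounds go, how a plain amino group or a phenylamino group without the nitrile would stand also remains open.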